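The source may report more compounds than this note shows. Statements on the series, on what has been measured and on what is new or still open speak of the compounds shown alone.

Of the compounds shown here, three that share one core have been tested in an ADME assay on THP-1 cells (Homo sapiens) for cytotoxicity; on this read-out higher numbers stand for weaker inhibition and lower numbers for stronger inhibition. Compound 1, `COc1ccccc1-c1nnc(-c2ccc(C(=O)N/N=C/c3cc(O)ccc3O)cc2)o1`, gives 100000 nM. Compound 2, `COc1ccccc1-c1nnc(-c2ccc(C(=O)N/N=C/c3ccccc3F)cc2)o1`, gives 313000 nM. Compound 3, `COc1ccccc1-c1nnc(-c2ccc(C(=O)N/N=C/c3ccc(O)cc3O)cc2)o1`, gives 104000 nM. On these numbers compound 3 stands second highest; its closest neighbour is compound 1, and the gap between them, a 1.0-fold higher number from compound 1 to compound 3 (0.02 log units; within the scatter), is within the scatter. Its furthest neighbour is compound 2, and the step of a 3.0-fold lower number from compound 2 to compound 3 (0.48 log units; beyond the scatter) is beyond the scatter but modest.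

Compound 4, `COc1ccc(O)c(/C=N/NC(=O)c2ccc(-c3nnc(-c4ccccc4OC)o3)cc2)c1`, has not yet been measured. It differs from compound 3 in one place: 2-hydroxy-5-methoxyphenyl in place of 2,4-dihydroxyphenyl on a carbon with a double bond to nitrogen. Within the data shown here, two measured steps bear on this. Exchanging one dihydroxyphenyl for the other, a 1.0-fold higher number from compound 1 to compound 3 (0.02 log units; within the scatter), changed nothing beyond the scatter. Replacing a dihydroxyphenyl by a fluorophenyl, a 3.1-fold higher number from compound 1 to compound 2 (0.50 log units; beyond the scatter), raised the number modestly. The group entering compound 4 keeps one hydroxy and brings a methoxy, so it sits between these two cases. The step expected in this assay is therefore small, a 1.3-fold higher number from compound 3 to compound 4 (0.13 log units; within the scatter), most likely within the scatter or slightly upward toward weaker inhibition. For compound 4 the estimated value is 140000 nM, with a range from 70000 nM to 300000 nM.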

Compound 4, half-maximal inhibitory concentration: 303000 nM
Beside the measured number, compound 4's estimate is 2.2-fold (0.34 log units) below it; measured number outside the range, above it.
By their numbers in this assay, from the lowest: compounds 1 and 3 (each within the scatter of the next); then compounds 4 and 2 (each within the scatter of the next).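

In this assay, methyl in place of hydrogen on an oxygen on an aromatic ring, a 3.0-fold higher number from compound 1 to compound 4 (0.48 log units; beyond the scatter), shows that this position responds to a change as small as one methyl, which the earlier swaps of whole groups could not show. Keeping a hydroxy on the ring does not hold the number down: a 2.9-fold higher number from compound 3 to compound 4 (0.46 log units; beyond the scatter), while a 1.0-fold lower number from compound 2 to compound 4 (0.01 log units; within the scatter) leaves the 2-hydroxy-5-methoxyphenyl compound level with the 2-fluorophenyl one, so among these four compounds the two dihydroxyphenyl groups stand apart from the other two groups. Nothing available here accounts for why this one methyl matters so much.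

The compounds shown do not separate the loss of the free hydroxy from the presence of the methyl, and a ring carrying a hydroxy and an amine, or a hydroxy and a plain chlorine, in that same place would help to tell these apart. As far as these compounds go, it also stays open whether a longer chain on that oxygen, such as ethyl or propyl, would raise the number further or change it no more than methyl does.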